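A Hydroxynaphthyl Group Replaces Dichlorophenyl on a Shared Core

The compounds below may be only part of what the source reports. "The series", "measured", "known", "first", "only" and "open" are said of these compounds alone.

Of the compounds shown here, two sharing one core have been measured so far. Compound 1 `Cc1ccc(C2C(C#N)=C(N)N(c3ccc(S(N)(=O)=O)cc3)C3=C2C(=O)CCC3)cc1` carries a 4-methylphenyl group on a saturated ring carbon, and compound 2 `N#CC1=C(N)N(c2ccc(S(N)(=O)=O)cc2)C2=C(C(=O)CCC2)C1c1ccc(Cl)cc1Cl` carries a 2,4-dichlorophenyl group on that carbon. In a functional assay on Ehrlich cells (Mus musculus) for antiproliferative activity, read by trypan blue exclusion, with a stated time of 2 h, tested at 50 ug/mL (a lower number here means a weaker effect, a higher number a stronger effect of the compound at the concentration tested), compound 1 gives 50%, while in this assay compound 2 gives 65%. For the measured compounds named here, compound 2 therefore stands highest of the two numbers, and the single measured step of a number 15 percentage points higher from compound 1 to compound 2 (beyond the scatter) shows that exchanging the aryl group on that saturated ring carbon produced a modest rise beyond the scatter.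

Compound 3 `N#CC1=C(N)N(c2ccc(S(N)(=O)=O)cc2)C2=C(C(=O)CCC2)C1c1c(O)ccc2ccccc12` has not yet been measured in this assay. It differs from compound 2 in one place: 2-hydroxynaphthalen-1-yl in place of 2,4-dichlorophenyl on a saturated ring carbon. Going by the values given here, the one measured step bears on it only indirectly, since it too exchanged the aryl group on the same saturated ring carbon, and it was modest in size. A single exchange of this kind cannot fix the direction for a quite different aryl group, so the expected step of a number 5 percentage points lower from compound 2 to compound 3 (within the scatter) is placed within the scatter, with a broad range around it. For compound 3 the expected value in this assay is 60%, with a range from 35% to 85%.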

Compound 3, a percentage reported as activity, at one concentration (the size of the read-out at that concentration, not a potency): 5%
The estimate for compound 3 lay 55 percentage points above the measured number, and the stated range ends above it.
By their numbers in this assay, from the lowest: compound 3; then compound 1; then compound 2.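

In this assay, the saturated ring carbon proves far less forgiving than the earlier pair suggested: 2-hydroxynaphthalen-1-yl in place of 2,4-dichlorophenyl gives a number 60 percentage points lower from compound 2 to compound 3 (beyond the scatter) and in place of 4-methylphenyl gives a number 45 percentage points lower from compound 1 to compound 3 (beyond the scatter), both large steps, and compound 3 is the weakest of the three. The aryl group on this carbon can therefore move the number strongly downward as well as modestly upward, and the two substituted phenyl groups both stand well clear of the hydroxynaphthyl group. This exchange adds a second six-membered aromatic ring and also brings a hydrogen-bond donor and acceptor, all in one step, and nothing measured here shows which of these changes matters or explains the fall.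

Still open, as far as these compounds go, is whether the hydroxyl group or the second aromatic ring accounts for the drop, a question that naphthalen-1-yl without the hydroxyl group and 2-hydroxyphenyl without the second ring could separate. From the compounds shown here alone, it is also open how a 2-methoxynaphthalen-1-yl group, with its oxygen capped by a methyl group, or a 2-aminophenyl group would behave on this same carbon.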